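A few compounds are considered here, and "the series" means these few. Any claim that something is new, unique, unknown or untested is made for them only; others in the source may bear on it.

Measured so far:
compound 1 `CCCCCCCCCCc1cc2cc(C(C)N(O)C(C)=O)ccc2o1` — 410 nM
compound 2 `COc1ccc2cc(-c3cc4cc(C(C)N(O)C(C)=O)ccc4o3)ccc2c1` — 120 nM
compound 3 `CC(c1ccc2oc(-c3ccccc3)cc2c1)N(O)C(=O)c1ccccc1` — 4830 nM

In an assay on RBL cells for inhibition of Polyunsaturated fatty acid 5-lipoxygenase (Rattus norvegicus) (a lower number here means a stronger inhibitor, a higher number a weaker inhibitor), compound 3 gives 4830 nM, the highest number of the three; its distance to compound 1 and to compound 2 is in each case beyond the usual scatter, so compound 3 is the weakest inhibitor of the measured set. Within the data shown here, compound 3 is also the only measured compound that carries a phenyl on the carbonyl carbon next to the amide-type nitrogen; compounds 1 and 2 carry no such phenyl there, and both sit lower.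

Compound 4 `CC(=O)OCC(=O)N(O)C(C)c1ccc2oc(-c3ccccc3)cc2c1` keeps the rest of compound 3 and changes only that carbonyl substituent: acetoxymethyl in place of phenyl on a carbonyl carbon. Among the measured compounds shown here, no pair of measured compounds differs in this one place, so the size of the step has to be judged from what the set shows. Since compound 3 stands alone at the top with 4830 nM and the two compounds without the phenyl on the carbonyl stand well below it, the removal of the phenyl is expected to lower the number, though by an uncertain amount. The expected step from compound 3 to compound 4 in this assay is a 3.2-fold lower number from compound 3 to compound 4 (0.51 log units; beyond the scatter). For compound 4 the estimate in this assay is 1500 nM, with a range from 400 nM to 5000 nM.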

Compound 4, half-maximal inhibitory concentration: 160 nM
The estimate for compound 4 lay 9.4-fold (0.97 log units) above the measured number; measured number below the stated range.
By their numbers in this assay, from the lowest: compounds 2 and 4 (each within the scatter of the next); then compound 1; then compound 3.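

In this assay, the pair compound 3 and compound 4 gives the series its first direct reading of the substituent on a carbonyl carbon: acetoxymethyl in place of phenyl gives a 30-fold lower number from compound 3 to compound 4 (1.48 log units; beyond the scatter), with the rest of the structure unchanged. The position therefore has a large effect on the number in this assay, and a ring is not required there, as compound 4 carries an open-chain substituent with no ring and is the stronger inhibitor of the pair. No supporting measurement on hand accounts for the size of this step.

This single change removes an aromatic ring and brings in two hydrogen-bond acceptors at once, so the pair cannot show which of these goes with the lower number. From the compounds shown here alone, whether the acetoxymethyl group itself is needed remains open, and a hydroxymethyl, a methoxymethyl or a benzyl group on the same carbonyl carbon, with the rest of compound 4 held constant, would help separate the loss of the phenyl from the arrival of the acetoxymethyl.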